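The compounds below may be only part of what the source reports. "The series", "measured", "known", "first", "only" and "open" are said of these compounds alone.

Measured in an ADME assay on the whole organism (Mus musculus, strain CB17) for pharmacokinetics, at a dose of 30 mg/kg by the oral route; a higher number here means more compound in the circulation at the dose given, a lower number less compound in the circulation:
- Compound 1 `C[C@@H](Oc1cc(C(=O)N(C)C)ccc1Nc1nc(O[C@H]2CC[C@@](C)(O)CC2)c2c(Cl)c[nH]c2n1)C(F)(F)F`: 12500 ng.h/mL
- Compound 2 `COc1cc(N2CCN(C3COC3)CC2)ccc1Nc1nc(O[C@H]2CCOC(C)(C)C2)c2cc[nH]c2n1`: 18000 ng.h/mL

Compound 1 and compound 2 lie within the usual scatter of each other in this assay, and compound 2 stands at 18000 ng.h/mL. Compound 3 `COc1cc(N2CCN(C(=O)CO)CC2)ccc1Nc1nc(O[C@H]2CCOC(C)(C)C2)c2cc[nH]c2n1` departs from compound 2 in one place: (hydroxymethyl)carbonyl in place of oxetan-3-yl on an amine nitrogen in a ring. In words, (hydroxymethyl)carbonyl stands in place of oxetan-3-yl on an amine nitrogen in a ring. Among the compounds with values here, no measured pair tests this exchange, and compound 1 differs from compound 2 in more than one place. The expectation therefore starts from compound 2 at 18000 ng.h/mL and remains a judgement with wide margins. A moderate fall beyond the scatter is expected, although no change at all cannot be ruled out. The expected step is a 2.6-fold lower number from compound 2 to compound 3 (0.41 log units; beyond the scatter). The estimate for compound 3 is 7000 ng.h/mL, with an expected range of 2000 ng.h/mL to 20000 ng.h/mL.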

Compound 3, area under the concentration-time curve: 8990 ng.h/mL
Compound 3: middle estimate off by 1.3-fold (0.11 log units), on the low side; low and high end bracket the measured number.
By their numbers in this assay, from the lowest: compounds 3, 1 and 2 (each within the scatter of the next).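

In this assay, the exchange of oxetan-3-yl for (hydroxymethyl)carbonyl on an amine nitrogen in a ring gives a 2.0-fold lower number from compound 2 to compound 3 (0.30 log units; within the scatter) and is the only one-place comparison among the compounds shown. Within the data shown here, at this position, then, a four-membered ring without a hydrogen-bond donor can give way to an open group of the same heavy-atom count that carries a hydrogen-bond donor and a carbonyl, with no step that can be told from the scatter. No measurement is at hand that would explain the step.

From the compounds shown here alone, whether a simple methyl group, an acetyl group or a carboxylic acid on that nitrogen would read the same remains open. This single pair also cannot say whether the exchange would read alike on a different core or at another dose.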